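This account rests on a few compounds, and the source may have more. Where it says the series, first, only, none or still open, it means among the compounds named here.

Within the data shown here, compound 2 `CC(C)(C)c1ccc(C(=O)Nc2cccc(NC(=O)COc3ccc4c(=O)ccoc4c3)c2)cc1` is the only compound here with a numbered result: in an assay on isolated protein for inhibition of Rho-associated protein kinase 1 (Homo sapiens), read by scintillation counting, radiometric assay and 33P incorporation, with a stated time of 40 min, in the presence of a further agent that is not named here (on this read-out lower numbers stand for stronger inhibition and higher numbers for weaker inhibition), compound 2 gives 165 nM. Compound 1 `Cc1coc2cc(OCC(=O)Nc3cccc(NC(=O)c4ccc(N(C)C)cc4)c3)ccc2c1=O` differs from it in several places at once and reaches only a limit of the assay, not a number. In this assay compound 1 gives > 10000 nM, which is the limit of the test (the limit of > 10000 nM in this assay, at which 1 of the 2 values shown sits). Among the measured compounds shown here, no pair among the measured compounds differs in a single place, so no measured step is available to guide the next change. Compound 3 `O=C(COc1ccc2c(=O)ccoc2c1)Nc1cccc(NC(=O)c2ccc([N+](=O)[O-])cc2)c1` is not yet measured. It arises from compound 2 by one change, nitro in place of tert-butyl on an aromatic carbon. For the measured compounds named here, with no measured step of this kind, the expectation rests on the change itself: a weakening beyond the usual scatter seems likely, though not a fall all the way to the limit. For compound 3 the expected step is a 9.1-fold higher number from compound 2 to compound 3 (0.96 log units; beyond the scatter). Compound 3 is estimated at 1500 nM, within a range from 300 nM to 8000 nM.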

Compound 3, half-maximal inhibitory concentration: 67 nM
The estimate for compound 3 lay 22-fold (1.35 log units) above the measured number; the measured number lies below the stated range.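

At this position, on the six-membered aromatic ring of carbon only and para to a large group, nitro in place of tert-butyl gives in this assay a 2.5-fold lower number from compound 2 to compound 3 (0.39 log units; beyond the scatter) and so a modest gain in inhibition. This is the first single-place step among these compounds, and it shows that tert-butyl is not needed here for inhibition at this level, since a group of nitrogen and oxygen in place of carbon only is accepted. No measurement shown here bears on what lies behind this gain.

From the compounds shown here alone, whether a carboxylic acid or a methoxy group at the same position would keep, raise or lose this inhibition stays open. In this assay compound 1 gives > 10000 nM as a limit of the assay, and it differs from compound 2 in several places, so the effects of its separate changes cannot be told apart.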